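The source may hold more compounds than are shown below. What is called first, only, known or untested is meant among the compounds shown, and "the series" means these compounds.

Measured so far in a functional assay on HGC-27 cells (Homo sapiens) for antiproliferative activity, read by MTT assay, with a stated time of 72 h; on this read-out lower numbers stand for stronger inhibition and higher numbers for weaker inhibition: compound 1 `CCCSc1nc(Nc2ccc(OC)cc2)c2nc(Nc3ccccc3)sc2n1` gives 30900 nM; compound 2 `CCCSc1nc(NC2CC2)c2nc(Nc3ccccc3)sc2n1` gives 32400 nM.

Compound 2 and compound 1 sit at the same level, since the step of a 1.0-fold higher number from compound 1 to compound 2 (0.02 log units; within the scatter) lies within the scatter. Compound 3 `CCCSc1nc(NCc2ccc(O)cc2)c2nc(Nc3ccccc3)sc2n1` differs from compound 2 by 4-hydroxybenzyl in place of cyclopropyl on a nitrogen on an aromatic ring. Within the data shown here, the only step measured, the one from compound 1 to compound 2, also replaced the group on this nitrogen and left the number where it was. No step beyond the scatter is therefore expected for compound 3: a 1.1-fold lower number from compound 2 to compound 3 (0.03 log units; within the scatter). Compound 3 is estimated at 30000 nM, within a range from 12000 nM to 80000 nM.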

Compound 3, half-maximal inhibitory concentration: 17300 nM
For compound 3 the middle estimate is 1.7-fold (0.24 log units) above the measured one; the range from low to high includes it.
By their numbers in this assay, from the lowest: compounds 3, 1 and 2 (each within the scatter of the next).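

In this assay, a third group on this nitrogen, 4-hydroxybenzyl, stays level with the other two, with a 1.9-fold lower number from compound 2 to compound 3 (0.27 log units; within the scatter) and a 1.8-fold lower number from compound 1 to compound 3 (0.25 log units; within the scatter). These are the largest steps seen so far at this position, yet neither leaves the scatter, so cyclopropyl, 4-methoxyphenyl and 4-hydroxybenzyl cannot be told apart here. No evidence is available that bears on this result. From the compounds shown here alone, whether a group such as a carboxylic acid, an aliphatic amine or a longer alkyl chain on this nitrogen would shift the number beyond the scatter stays open.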